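Acetyl in Place of Pyridinyloxy: Expected Effect on Cytotoxicity

The source may hold more compounds than are shown below. What is called first, only, known or untested is meant among the compounds shown, and "the series" means these compounds.

Measured compounds:
compound 1 `O=C(Nc1cccc(Oc2ccccn2)c1)C1CCCN(C(=O)c2cc(C(F)(F)F)cc(C(F)(F)F)c2)C1` – 0%
compound 2 `O=C(Nc1cccc(Cc2ccccc2)c1)C1CCCN(C(=O)c2cccc(-c3ccco3)c2)C1` – 0%

Of the compounds shown here, two built on a shared core have been tested in an ADME assay on PC-3 cells (Homo sapiens) for cytotoxicity, read by WST assay, tested at 100 uM; a lower number here means less inhibition, a higher number more inhibition at the concentration tested (going by the name of the read-out). In this assay compound 1 gives 0%. Compound 2 gives 0% in this assay. Compound 1 therefore stands level with compound 2 at the digits shown; the two readings agree within the usual scatter, so no order between them can be drawn. Within the data shown here, no pair of measured compounds differs in only one place, so no single-point step is available as a yardstick.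

Compound 3 `CC(=O)c1cccc(NC(=O)C2CCCN(C(=O)c3cc(C(F)(F)F)cc(C(F)(F)F)c3)C2)c1` has not yet been measured. Compared with compound 1 the change is acetyl in place of (pyridin-2-yl)oxy on an aromatic carbon. Since compound 1 shows 0% in this assay, and nothing in the two measured compounds points to cytotoxicity, the step is expected to be none beyond the scatter: a number 2 percentage points higher from compound 1 to compound 3 (within the scatter) is the estimated change. Compound 3 is thus expected to give 2% in this assay, with a plausible range from -8% to 15%.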

Compound 3, a percentage reported as inhibition, at one concentration (the size of the read-out at that concentration, not a potency): 0%
For compound 3 the middle estimate is 2 percentage points above the measured one; the measured number falls inside the stated range.
By their numbers in this assay, from the lowest: compounds 1, 2 and 3 (each within the scatter of the next).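

In this assay, among these compounds, placing acetyl instead of (pyridin-2-yl)oxy on this aromatic carbon gives no change at the digits printed from compound 1 to compound 3 (within the scatter) and provides the first comparison here between two compounds that differ in only one place. At this position, meta to a large group, the six-membered aromatic ring with its hetero atom can therefore be removed and the smaller acetyl, which has no ring, put in its place without any detectable difference in this reading at the single concentration tested. No supporting measurement bears on why the reading stays level between these two compounds.

With both compounds reading no inhibition, this single step cannot show whether any group at this position would raise the number, or how far acetyl and (pyridin-2-yl)oxy would differ in a compound that does inhibit the cells. It also leaves open what a basic amine, a carboxylic acid or a longer alkyl chain on this same aromatic carbon would do in this assay.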